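Methoxycarbonyl Added to Compound 1: Expected Clearance

This account rests on a few compounds, and the source may have more. Where it says the series, first, only, none or still open, it means among the compounds named here.

Going by the values given here, compound 1 `CC(C)c1ccc2c(Nc3cc(C(=O)N[C@@H](C)c4ccccc4)ccc3Sc3ccc(N)cc3)ncnc2n1` has been measured in an ADME assay on the whole organism (strain Sprague-Dawley) for pharmacokinetics, with Rattus norvegicus as the target, at a dose of 5 mg/kg by the intravenous route (a higher number here means faster removal of the compound, a lower number slower removal), where compound 1 gives 5.5 mL/min/kg, the lower of the two numbers known so far. Compound 2 `CC(C)c1ccc2c(Nc3cc(C(=O)N[C@@](C)(CO)c4ccccc4)ccc3Sc3ccc(N)cc3)ncnc2n1` gives 12.5 mL/min/kg, and the change a 2.3-fold higher number from compound 1 to compound 2 (0.36 log units; beyond the scatter) is modest. Compound 3 `COC(=O)Nc1ccc(Sc2ccc(C(=O)N[C@@H](C)c3ccccc3)cc2Nc2ncnc3nc(C(C)C)ccc23)cc1` differs from compound 1 by methoxycarbonyl in place of hydrogen on a nitrogen on an aromatic ring. No measured step involves this change; the hydroxymethyl step concerns another place in the molecule, so nothing shown points in either direction. Compound 3 is therefore expected to remain within the scatter of compound 1, at a 1.3-fold higher number from compound 1 to compound 3 (0.10 log units; within the scatter). Compound 3 is estimated at 7 mL/min/kg, between 3.5 mL/min/kg and 14 mL/min/kg.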

Compound 3, clearance: 12.8 mL/min/kg
Estimate against measurement, compound 3: 1.8-fold (0.26 log units) below; measured number inside the range.
By their numbers in this assay, from the lowest: compound 1; then compounds 2 and 3 (each within the scatter of the next).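

In this assay, methoxycarbonyl in place of hydrogen on this aromatic amino nitrogen gives a 2.3-fold higher number from compound 1 to compound 3 (0.37 log units; beyond the scatter) and so shows that this end of the molecule can also alter how fast the compound is removed. The earlier compounds shown here showed a change only at the amide side chain. No evidence at hand bears on what lies behind this rise.

On these data alone, what remains open is whether the rise is specific to methoxycarbonyl. An acetyl or a methyl group on the same nitrogen could separate the effect of the carbonyl from that of simply replacing the hydrogen.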